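Swapping a trifluoromethylphenyl for pyridin-2-yl on sulfur

The compounds below may be only part of what the source reports. "The series", "measured", "known", "first", "only" and "open" are said of these compounds alone.

Measured compounds:
Compound 1, `CC(O)(C[S+]([O-])c1ccc(C(F)(F)F)cn1)C(=O)Nc1ccc([N+](=O)[O-])cc1C(F)(F)F`: > 100000 nM; > 100000 nM (2 entries)
Compound 2, `CC(O)(C[S+]([O-])c1ccc(F)c(F)c1)C(=O)Nc1ccc([N+](=O)[O-])cc1C(F)(F)F`: > 100000 nM; > 100000 nM (2 entries)
Compound 3, `CC(O)(C[S+]([O-])c1ccc(C(F)(F)F)cc1)C(=O)Nc1ccc([N+](=O)[O-])cc1C(F)(F)F`: 25600 nM

Three compounds share one core and differ only in the aromatic ring attached to the sulfur. In a functional assay on LNCaP cells (Homo sapiens) for antiproliferative activity (a lower number here means a stronger inhibitor, a higher number a weaker inhibitor), compound 3 gives 25600 nM. Among the measured compounds shown here, this is the only actual number in the set. For compound 1 the result is > 100000 nM; > 100000 nM (2 entries). For compound 2 the result is likewise > 100000 nM; > 100000 nM (2 entries). For the measured compounds named here, compound 3 therefore stands alone as the one compound with a measurable value, and nothing can be said about order among the three beyond that.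

Compound 4, `CC(O)(C[S+]([O-])c1ccccn1)C(=O)Nc1ccc([N+](=O)[O-])cc1C(F)(F)F`, has not been measured. It differs from compound 3 by pyridin-2-yl in place of 4-(trifluoromethyl)phenyl on a sulfur. Compound 1, which also carries a pyridin-2-yl ring on the sulfur, gives > 100000 nM; > 100000 nM (2 entries). The step from compound 3 to compound 4 is expected to weaken inhibition, roughly a 2.3-fold higher number from compound 3 to compound 4 (0.37 log units; beyond the scatter). Compound 4 is estimated at 60000 nM, within a range from 20000 nM to 200000 nM.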

Compound 4, half-maximal inhibitory concentration: > 100000 nM
Compound 4: a limit, no number; the forecaster's own chance of this, stated with the estimate: 45%; middle value at least 1.6-fold (0.22 log units) from the limit.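

In this assay compound 4 gives > 100000 nM, which is a limit of the assay and not a number. Even so, pyridin-2-yl in place of 4-(trifluoromethyl)phenyl on the sulfur gives the first step in this set that can be read, an at least 3.9-fold higher number from compound 3 to compound 4 (0.59 log units; beyond the scatter), so this position does respond to a change of ring. That step is only a minimum, and its full size stays unknown, as the result for compound 4 is a limit: the limit of > 100000 nM in this assay, at which 1 of the 4 values shown sits.

The change removes the trifluoromethyl group and brings in a ring nitrogen at the same time, and the compounds shown do not separate these two parts. Going by these compounds, how a plain phenyl ring or a ring carrying an amine on the sulfur would compare also remains open.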